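The compounds below may be only part of what the source reports. "The series", "measured", "known", "first", "only" and "open" are said of these compounds alone.

Of the compounds shown here, three have already been measured in an ADME assay on microsomes from liver (Canis lupus familiaris) for metabolic stability, read by LC-MS, using NADPH, with a stated time of 30 min, tested at 1 uM (on this read-out higher numbers stand for a more stable compound and lower numbers for a less stable compound), and a fourth is waiting for its reading. Compound 2 `C=CC(=O)Nc1cc(Nc2nccc(Nc3ccccc3S(=O)(=O)N(C)C)n2)c(OC)cc1N(C)CCN(C)C` gives 50% in this assay. Compound 1 `C=CC(=O)Nc1cc(Nc2ncc(I)c(Nc3ccccc3S(=O)(=O)N(C)C)n2)c(OC)cc1N(C)CCN(C)C` carries a single change relative to compound 2, (iodo in place of hydrogen on an aromatic carbon), and in this assay compound 1 gives 35%; the measured step is a number 15 percentage points lower from compound 2 to compound 1 (beyond the scatter). Compound 3 `C=CC(=O)Nc1cc(Nc2nccc(Nc3ccccc3S(=O)(=O)C(C)C)n2)c(OC)cc1N(C)CCN(C)C` differs from compound 2 at another point, (isopropyl in place of dimethylamino on a sulfonyl sulfur), and in this assay compound 3 gives 48%; the measured step is a number 2 percentage points lower from compound 2 to compound 3 (within the scatter), so the two cores stand at the same level in this assay.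

Compound 4 `C=CC(=O)Nc1cc(Nc2ncc(I)c(Nc3ccccc3S(=O)(=O)C(C)C)n2)c(OC)cc1N(C)CCN(C)C` is not yet measured. It differs from compound 3 by iodo in place of hydrogen on an aromatic carbon. Among the measured compounds shown here, this is the same change as the one from compound 2 to compound 1, made here on the core of compound 3 rather than on that of compound 2, and the surroundings of the changed position read alike in both cases. For the measured compounds named here, only one measured example of this change exists, so the expectation rests on it alone. Going by the values given here, because the only measured example of this change is a number 15 percentage points lower from compound 2 to compound 1 (beyond the scatter), a step of similar size is expected for compound 4, a number 15 percentage points lower from compound 3 to compound 4 (beyond the scatter). Compound 4 is therefore estimated at 33% in this assay, with a likely range from 22% to 45%.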

Compound 4, percent of the compound remaining: 19%
The estimate for compound 4 lay 14 percentage points above the measured number; the measured number lies below the stated range.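

In this assay, iodo in place of hydrogen on the core of compound 3 gives a number 29 percentage points lower from compound 3 to compound 4 (beyond the scatter) and so moves the number in the same direction as on the core of compound 2, with no measurable difference in the size of the two steps: the same change on two cores in this assay, a number 15 percentage points lower (beyond the scatter) from compound 2 to compound 1 and a number 29 percentage points lower (beyond the scatter) from compound 3 to compound 4, 14 percentage points apart, within the scatter of two such steps. Read the other way, isopropyl in place of dimethylamino on a sulfonyl sulfur gives a number 16 percentage points lower from compound 1 to compound 4 (beyond the scatter) once the iodo is present, and this step also cannot be told apart from its earlier counterpart: the same change on two cores in this assay, a number 2 percentage points lower (within the scatter) from compound 2 to compound 3 and a number 16 percentage points lower (beyond the scatter) from compound 1 to compound 4, 14 percentage points apart, within the scatter of two such steps. Within this pair of cores, the iodo change therefore carries over in direction, and the numbers give no firm sign that one core responds differently from the other, but two examples do not prove that the steps are equal in size or show that the same would hold on any further core.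

The compounds shown leave open whether chloro, fluoro or methyl on the same aromatic carbon would lower the number as iodo does. They also leave open how a cyclopropyl or a longer alkyl chain on the sulfonyl sulfur would compare with isopropyl and dimethylamino, with or without iodo on the core.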